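The source may report more compounds than this note shows. Statements on the series, on what has been measured and on what is new or still open speak of the compounds shown alone.

Of the compounds shown here, two have so far been measured in a functional assay on the whole organism (Tail, strain ICR) with Mus musculus as the target, in the tail flick test, with a stated time of 120 min, at a dose of 25 umol/kg by the oral route; on this read-out higher numbers stand for a stronger effect at the one dose given and lower numbers for a weaker effect. Compound 1, `C[C@H](NC(=O)CN(c1nc(Cl)nc2[nH]cnc12)C1CC1)C(=O)OCc1ccccc1`, gives 36.1% in this assay. Compound 2, `N=C(N)NCCC[C@H](NC(=O)CN(c1ncnc2c1ncn2C1CCCCO1)C1CC1)C(=O)OCc1ccccc1`, gives 38.2% in this assay. The gap between these two numbers lies within the usual scatter of repeated measurements of this kind, so the two compounds cannot be told apart on this read-out, and compound 1 simply stands alongside compound 2 rather than apart from it.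

The next compound, compound 3, `CC(C)C[C@H](NC(=O)CN(c1nc(Cl)nc2[nH]cnc12)C1CC1)C(=O)OCc1ccccc1`, has not yet been measured in this assay. It arises from compound 1 by a single change: isopropyl in place of hydrogen on a saturated chain carbon, two bonds along the chain from an amide-type nitrogen and a carbonyl carbon. Within the data shown here, no pair of measured compounds differing in just one place is available, so the size of such a step cannot be read from earlier numbers. With nothing in the data pointing either way, the step is expected to be small, a number 3.9 percentage points higher from compound 1 to compound 3 (within the scatter), that is, no change beyond the scatter. Compound 3 is accordingly estimated to give 40% in this assay, within a range from 20% to 62%.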

Compound 3, a percentage reported as activity, at one dose (the size of the read-out at that dose, not a potency): 8.58%
For compound 3 the middle estimate is 31.4 percentage points above the measured one; the measured number lies below the stated range.
By their numbers in this assay, from the lowest: compound 3; then compounds 1 and 2 (each within the scatter of the next).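

In this assay, the swap of isopropyl for hydrogen on a saturated chain carbon, two bonds along the chain from an amide-type nitrogen and a carbonyl carbon, gives a number 27.5 percentage points lower from compound 1 to compound 3 (beyond the scatter). Among these compounds, this is the first single-place step that can be read here, and it shows that this position is not indifferent: turning the methyl of compound 1 into the isobutyl of compound 3 weakens the effect at the one dose given, even though the added group carries no ring, no hydrogen-bond donor or acceptor, and no net charge. Nothing available explains this drop, so the numbers record the loss without giving its cause.

One step cannot show whether the loss comes with any growth at this carbon or only with this branched group, and an ethyl group or a straight propyl chain would help to separate those two cases. It also leaves open how this position would respond to a group of another kind, such as an amine, a hydroxyl or a carboxylic acid, since compound 2 differs from compound 1 in more than one place and cannot answer that.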